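Sulfonylpiperazine acetanilides: removing the ortho-fluoro on compound 3

A few compounds are considered here, and "the series" means these few. Any claim that something is new, unique, unknown or untested is made for them only; others in the source may bear on it.

The series shares a piperazine core carrying an arylsulfonyl group and an acetanilide arm. Compound 1 `COc1ccc(NC(=O)CN2CCN(S(=O)(=O)c3ccc(F)cc3)CC2)cc1` gives 29600 nM in an in vitro assay on HEK ts201 cells for negative allosteric modulation of Neuronal acetylcholine receptor; alpha3/beta4 (Homo sapiens), read by fluorescence and calcium flux, with a stated time of 1.5 s; on this read-out lower numbers stand for stronger inhibition and higher numbers for weaker inhibition. Going by the values given here, compound 2 `O=C(CN1CCN(S(=O)(=O)c2ccc(F)cc2)CC1)Nc1ccccc1` gives 18500 nM in this assay; the step of a 1.6-fold lower number from compound 1 to compound 2 (0.20 log units; within the scatter) is the only single-point comparison measured so far. Compound 3 `O=C(CN1CCN(S(=O)(=O)c2ccccc2F)CC1)Nc1ccccc1F` gives 99800 nM in this assay, the highest of the three numbers, with both other compounds beyond the scatter below it.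

Compound 4 `O=C(CN1CCN(S(=O)(=O)c2ccccc2)CC1)Nc1ccccc1F` follows from compound 3 by hydrogen in place of fluoro on an aromatic carbon, on the sulfonyl-bearing ring, ortho to a large group. Among the compounds with values here, no measured step touches this ring, and the step from compound 1 to compound 2 concerns the other aryl ring only. Compound 2 and compound 3 differ at two places at once, so their values set a loose bracket rather than a guide. The change for compound 4 is expected to give a 2.0-fold lower number from compound 3 to compound 4 (0.30 log units; within the scatter), toward stronger inhibition but with wide uncertainty. For compound 4 in this assay the estimate is 50000 nM, with a range from 20000 nM to 120000 nM.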

Compound 4, half-maximal inhibitory concentration: 4000 nM
Beside the measured number, compound 4's estimate is 13-fold (1.10 log units) above it; measured number outside the range, below it.
By their numbers in this assay, from the lowest: compound 4; then compounds 2 and 1 (each within the scatter of the next); then compound 3.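

Hydrogen in place of fluoro on the sulfonyl-bearing ring, ortho to a large group, gives a 25-fold lower number from compound 3 to compound 4 (1.40 log units; beyond the scatter) in this assay, the first measured step at this ring. Going by these compounds alone, the only earlier step, a 1.6-fold lower number from compound 1 to compound 2 (0.20 log units; within the scatter), concerns the other aryl ring and lies within the scatter, whereas this single replacement is large and beyond it, so this position responds strongly to 2-fluorophenyl to phenyl on this scaffold. Nothing available explains the size of this step.

On these data alone, compound 3 and compound 4 both keep the fluoro on the anilide ring, so whether the step holds with an unsubstituted anilide ring remains open. As far as these compounds go, how a chloro, a methyl or an amine at this position would compare with hydrogen and fluoro also remains open.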